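From Acetyl to Pyrrolidinylcarbonyl on a Shared Core

A few compounds are considered here, and "the series" means these few. Any claim that something is new, unique, unknown or untested is made for them only; others in the source may bear on it.

Compound 1 `CC(=O)N(Cc1ccccc1-c1ccccc1)[C@H]1CCNC1` carries an acetyl group on the amide-type nitrogen of the shared core; in an assay on HEK293 cells for inhibition of sodium-dependent dopamine transporter (Homo sapiens) (a lower number here means a stronger inhibitor, a higher number a weaker inhibitor), compound 1 gives "not determined" (no result reported). For the measured compounds named here, the only measured comparator is compound 2 `CS(=O)(=O)N(Cc1ccccc1C(F)(F)F)[C@H]1CCNC1`, which in this assay gives 2890 nM. Compound 3 `O=C(N1CCCC1)N(Cc1ccccc1-c1ccccc1)[C@H]1CCNC1` differs from compound 1 by pyrrolidin-1-yl in place of methyl on a carbonyl carbon. Going by the values given here, no step between measured compounds exists, so the size and direction of this change cannot be anchored; the author expects at most a modest shift. Compound 3 is expected to give about 2000 nM in this assay, within a range from 400 nM to 10000 nM.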

Compound 3, inhibition constant: 4190 nM
Beside the measured number, compound 3's estimate is 2.1-fold (0.32 log units) below it; the measured number falls inside the stated range.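

No step can be read between compound 1 and compound 3 in this assay, where compound 3 gives 4190 nM. On these data alone, the effect of replacing methyl with pyrrolidin-1-yl on this carbonyl carbon stays open. No supporting evidence bears on this result.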